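A few compounds are considered here, and "the series" means these few. Any claim that something is new, unique, unknown or untested is made for them only; others in the source may bear on it.

Measured so far:
- compound 1, `C/N=C(\S)NCCCCCn1nc(-c2ccccc2)ccc1=O`: 35.3 mg/kg
- compound 2, `C=CCNC(=S)NCCCCn1nc(-c2ccccc2)ccc1=O`: > 100 mg/kg

Compound 2 stands at the limit of the method: in a functional assay on the whole organism (stomach) with Rattus norvegicus as the target (a lower number here means that less compound is needed, a higher number that more compound is needed for the effect), compound 2 gives > 100 mg/kg, which is a limit and not a number (the limit of > 100 mg/kg in this assay, at which 1 of the 2 values shown sits). For the measured compounds named here, compound 1 gives 35.3 mg/kg in this assay, and the step of an at least 2.8-fold higher number from compound 1 to compound 2 (0.45 log units; beyond the scatter) is the only measured step.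

Compound 3, `CN(C)/C(=N/CCCn1nc(-c2ccccc2)ccc1=O)NC#N`, is yet to be measured. It differs from compound 2 by a group of 8 heavy atoms (4 carbon, 4 nitrogen; no ring) in place of a group of 8 heavy atoms (5 carbon, 2 nitrogen, 1 sulfur; no ring), on a saturated chain carbon, three bonds along the chain from an aromatic nitrogen.

Going by the values given here, no measured step exchanges this group; the one step measured, from compound 1 to compound 2, changes a different part of the chain and starts from a number while compound 2 is only a limit. The direction of the step to compound 3 in this assay is therefore open, and the estimate for compound 3 is set near the measured range of the series with a wide spread. Compound 3 is expected to give 60 mg/kg, between 20 mg/kg and 180 mg/kg, which would mean a step of an at least 1.6-fold lower number from compound 2 to compound 3 (0.22 log units; that floor lies within the scatter) and is an expectation only, with a fair chance that only a limit is reported again.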

Compound 3, dose for half-maximal effect: 53 mg/kg
Compound 3: middle estimate off by 1.1-fold (0.05 log units), on the high side; measured number inside the range.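

In this assay the group of 8 heavy atoms (4 carbon, 4 nitrogen), on a saturated chain carbon, three bonds along the chain from an aromatic nitrogen, gives a measured number, so a group without sulfur at this position is compatible with the effect. Compound 2 gives > 100 mg/kg here, which is a limit and not a number. The exchange reads as an at least 1.8-fold lower number from compound 2 to compound 3 (0.27 log units; that floor lies within the scatter) with its true size unknown, and a 1.5-fold higher number from compound 1 to compound 3 (0.18 log units; within the scatter) leaves no separation between those two compounds.

Open, going by these compounds, is whether an amine or a carboxylic acid at this position would also give a number in this assay. Also open, on these data alone, is how a longer chain carrying the group of 8 heavy atoms would read.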